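From tert-butyl to methyl on compound 3

A few compounds are considered here, and "the series" means these few. Any claim that something is new, unique, unknown or untested is made for them only; others in the source may bear on it.

Compound 1 (`FC(F)(F)c1cc(/N=C2/NC/C(=C/c3ccccc3)S2)cc(C(F)(F)F)c1`) stands at 32800 nM in an ADME assay on TERT-RPE1 cells (Homo sapiens) for cytotoxicity, read by MTT assay, with a stated time of 72 h (on this read-out higher numbers stand for weaker inhibition and lower numbers for stronger inhibition), and serves as the first reference point for the series. Compound 3 (`COc1ccc(/C=C2\S/C(=N\c3ccc(C(C)(C)C)cc3)N(C)C2=O)cc1`) stands at 46700 nM in this assay and lies within the scatter of compound 1. Compound 2 (`S=C(Nc1ccccc1)N1C/C(=C/c2ccccc2)S/C1=N\c1ccccc1`) gives > 100000 nM as a limit of the assay and not a number.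

Compound 4 (`COc1ccc(/C=C2\S/C(=N\c3ccc(C)cc3)N(C)C2=O)cc1`) has methyl in place of tert-butyl on an aromatic carbon, para to a large group (methyl in place of tert-butyl on an aromatic carbon). Within the data shown here, no two measured compounds differ in one place, so no measured step gives the size of this change directly. The expectation therefore rests on compound 3 at 46700 nM as the closest structure, and no step beyond the scatter is expected in this assay for this replacement. The step expected is a 1.1-fold higher number from compound 3 to compound 4 (0.03 log units; within the scatter) and is estimated to stay within the scatter. For compound 4 the estimate is 50000 nM with an expected range from 20000 nM to 100000 nM in this assay when the measurement is made.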

Compound 4, half-maximal inhibitory concentration: > 100000 nM
Compound 4: only a limit was reported; the forecaster's own chance of this, stated with the estimate: 15%; at least 2.0-fold (0.30 log units) between middle value and limit.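

In this assay, among these compounds, the aromatic carbon para to a large group is the first place where a single change can be read: methyl in place of tert-butyl gives an at least 2.1-fold higher number from compound 3 to compound 4 (0.33 log units; beyond the scatter). Compound 4 gives > 100000 nM, which is a limit of the assay and not a number. The step therefore has a lower bound but no fixed size, because the read-out ends at this limit: the limit of > 100000 nM in this assay, at which 2 of the 4 values shown sit.

Only tert-butyl and methyl are shown at this position, so it remains open whether an ethyl group, a longer chain, an amine or a carboxylic acid there would give a value inside the range of the assay. Compound 1 and compound 2 differ from compound 3 in more than one place and give no further reading of this change.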